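The source may hold more compounds than are shown below. What is called first, only, known or untested is meant among the compounds shown, and "the series" means these compounds.

In a functional assay on SK-BR-3 cells (Homo sapiens) for antiproliferative activity, read by XTT assay, with a stated time of 72 h (a higher number here means a weaker inhibitor, a lower number a stronger inhibitor), compound 1 (`COc1ccc(C(=O)/C=C/c2nc3ccccc3cc2-c2ccc(OC)cc2)cc1`) gives 9280 nM and compound 2 (`COc1ccc(-c2cc3ccccc3nc2/C=C/C(=O)c2ccc(OC)c(OC)c2)cc1`) gives 3260 nM while compound 3 (`COc1ccc(-c2cc3ccccc3nc2/C=C/C(=O)c2ccc([N+](=O)[O-])cc2)cc1`) gives 590 nM as the lowest of the three numbers. Compound 4 (`COc1ccc(-c2cc3ccccc3nc2/C=C/C(=O)c2sccc2N)cc1`) is still unmeasured and differs from compound 3 by 3-aminothiophen-2-yl in place of 4-nitrophenyl on a carbonyl carbon. The nearest measured change at that carbonyl carbon is a 5.5-fold lower number from compound 2 to compound 3 (0.74 log units; beyond the scatter) and the widest is a 16-fold lower number from compound 1 to compound 3 (1.20 log units; beyond the scatter) while a 2.8-fold lower number from compound 1 to compound 2 (0.45 log units; beyond the scatter) also bears on it. Within the data shown here, only compound 3 carries 4-nitrophenyl and no measured compound carries 3-aminothiophen-2-yl. A modest step to a higher number is therefore expected in this assay (a 3.1-fold higher number from compound 3 to compound 4 (0.48 log units; beyond the scatter)). For compound 4 the estimated value is 1800 nM (expected range 400 nM to 7000 nM).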

Compound 4, half-maximal inhibitory concentration: > 10000 nM
Compound 4: a limit, no number; the forecaster's own chance of this, stated with the estimate: 3%; at least 5.5-fold (0.74 log units) between middle value and limit.
By their numbers in this assay, from the lowest: compound 3; then compound 2; then compound 1. At a limit, above all of these: compound 4.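

In this assay compound 4 gives > 10000 nM, which is a limit of the assay and not a number. On this carbonyl carbon, 3-aminothiophen-2-yl gives an at least 16-fold higher number from compound 3 to compound 4 (1.22 log units; beyond the scatter), an at least 3.0-fold higher number from compound 2 to compound 4 (0.48 log units; beyond the scatter) and an at least 1.0-fold higher number from compound 1 to compound 4 (0.03 log units; that floor lies within the scatter), so the position also allows a large step to a higher number, where the earlier changes had only lowered it.

The compounds shown do not separate the thiophene ring from its amine. An aminophenyl group or an unsubstituted thiophene on this carbon would bear on that question.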